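Working notes: from compound 2 to compound 4

This account rests on a few compounds, and the source may have more. Where it says the series, first, only, none or still open, it means among the compounds named here.

Measured in an ADME assay on CEM-SS cells (Homo sapiens) for cytotoxicity, read by XTT assay, with a stated time of 6 days; a lower number here means that less compound is tolerated, a higher number that more compound is tolerated:
- compound 1 (`CCCC(=O)OCSc1ccccc1C(=O)NC1(C(N)=O)CCCC1`) gives > 100 uM as a limit of the assay
- compound 2 (`CCCC(=O)OCSc1ccccc1C(=O)NCCCCCCNC(C)=O`) gives 8 uM as a single entry
- compound 3 (`CCCC(=O)OCSc1ccccc1C(=O)N[C@H]1CCC[C@@H]1C(N)=O`) gives 31.2 uM; 43.3 uM (2 entries) in two entries

Not yet measured: compound 4 (`CCCC(=O)OCSc1ccccc1C(=O)NCC(=O)OC`).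

Within the data shown here, compound 2, at 8 uM, is the only single number in the set, and it reads lower than the several entries of compound 3 in this assay, 31.2 uM; 43.3 uM (2 entries). Compound 1 offers no number, only (the limit of > 100 uM in this assay, at which 1 of the 3 values shown sits).

The change to compound 4 is methoxycarbonyl in place of 5-acetamidopentyl on a saturated chain carbon bound to an amide-type nitrogen.

Among the measured compounds shown here, no measured step covers this change, so any forecast carries a wide margin. A rise in this assay beyond the usual scatter is expected, meaning more compound tolerated. The support is thin, resting on compound 2 (8 uM) and compound 3 (31.2 uM; 43.3 uM (2 entries)), of which compound 3 reads the higher. The expected size of the move is a 3.8-fold higher number from compound 2 to compound 4 (0.57 log units; beyond the scatter) in this direction. Compound 4 is estimated at 30 uM, with an expected range from 10 uM to 100 uM.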

Compound 4, half-maximal toxic concentration: 27.3 uM
Beside the measured number, compound 4's estimate is 1.1-fold (0.04 log units) above it; low and high end bracket the measured number.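

In this assay, the change at this place, on a saturated chain carbon bound to an amide-type nitrogen, gives a first readable step, a 3.4-fold higher number from compound 2 to compound 4 (0.53 log units; beyond the scatter), so the low number of compound 2 is not fixed by the shared core and moves when methoxycarbonyl stands in place of 5-acetamidopentyl. The step with (methoxycarbonyl)methyl in place of 1-carbamoylcyclopentyl on an amide-type nitrogen, an at least 3.6-fold lower number from compound 1 to compound 4 (0.56 log units; beyond the scatter), shows that this smaller group does not reach the tolerance seen with the cyclopentyl-bearing compound, and its size is open-ended. Compound 1 remains a limit of the assay rather than a number: the limit of > 100 uM in this assay, at which 1 of the 4 values shown sits.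

The step from 5-acetamidopentyl to methoxycarbonyl alters the chain length and the end group at once, and the compounds shown do not separate the two. Open too, as far as these compounds go, is how the number moves at this place with a free carboxylic acid, a primary amine or a plain alkyl chain of intermediate length.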